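Amide series: cytotoxicity notes before compound 4

The source may report more compounds than this note shows. Statements on the series, on what has been measured and on what is new or still open speak of the compounds shown alone.

compound 1 `CC(CN(C)C)NC(=O)c1cc(C2CC2)nc2c1cnn2C(C)C` — > 300000 nM
compound 2 `CC(C)n1ncc2c(C(=O)NCCCN(C)C)cc(C3CC3)nc21` — > 200000 nM
compound 3 `CC(CN(C)C)NC(=O)c1cc(C(C)C)nc2c1cnn2C(C)C` — 117000 nM

Going by the values given here, in an ADME assay on Vero cells (Chlorocebus sabaeus) for cytotoxicity, read by neutral red uptake, with a stated time of 3 days (a lower number here means that less compound is tolerated, a higher number that more compound is tolerated), compound 3 gives 117000 nM, the only number in the set. Compound 1 reaches only a limit of this assay, > 300000 nM. Compound 2 likewise reaches only a limit, > 200000 nM. Among the compounds with values here, the one readable step is an at least 2.5-fold lower number from compound 1 to compound 3 (0.40 log units; beyond the scatter), on an aromatic carbon of the shared core. Compound 4 `CC(CN)NC(=O)c1cc(C(C)C)nc2c1cnn2C(C)C` differs from compound 3 by amino in place of dimethylamino on a saturated chain carbon, two bonds along the chain from an amide-type nitrogen. Within the data shown here, no measured step covers this change; the only alteration on the chain at the amide-type nitrogen is a step that the two limits leave unreadable from compound 1 to compound 2. A step beyond the scatter is therefore not expected in either direction. Compound 4 is estimated at 150000 nM (range 60000 nM to 400000 nM), an expected step of a 1.3-fold higher number from compound 3 to compound 4 (0.11 log units; within the scatter).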

Compound 4, half-maximal cytotoxic concentration: 135000 nM
Compound 4: middle estimate off by 1.1-fold (0.05 log units), on the high side; low and high end bracket the measured number.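

On a saturated chain carbon, two bonds along the chain from an amide-type nitrogen, amino in place of dimethylamino gives a 1.2-fold higher number from compound 3 to compound 4 (0.06 log units; within the scatter) in this assay. Going by these compounds alone, this is the only readable step on the chain at the amide-type nitrogen, and the exchange of dimethylamino for amino stays within the scatter. Nothing shown gives a cause for this step.

Open at this place are methylamino, a pyrrolidine ring and a carboxylic acid. Also open, from the compounds shown here alone, is how amino reads with cyclopropyl on the aromatic carbon, in place of isopropyl.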